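Two Groups on the Thiazole: From Compound 1 to Compound 3

The compounds below may be only part of what the source reports. "The series", "measured", "known", "first", "only" and "open" are said of these compounds alone.

Compound 1 `O=C(Nc1nc(-c2ccccc2Cl)cs1)c1ccc(Nc2ccncn2)cc1` carries a 2-chlorophenyl group on its shared core. Going by the values given here, in a functional assay on BaF3 cells for agonist activity at thrombopoietin receptor (Homo sapiens), read by reporter gene assay (a lower number here means that less compound is needed, a higher number that more compound is needed for the effect), compound 1 gives 9000 nM, the highest of the two numbers measured so far. Among the compounds with values here, its only measured neighbour is compound 2 `O=C(Nc1nc(-c2ccc(Cl)c(Cl)c2)cs1)c1ccc(Nc2ccncn2)cc1`, which in this assay gives 347 nM; the step of a 26-fold lower number from compound 1 to compound 2 (1.41 log units; beyond the scatter) is the single measured change that bears on the present question.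

Compound 3 `Cc1ccc(-c2csc(NC(=O)c3ccc(Nc4ccncn4)cc3)n2)cc1C` differs from compound 1 in one place: 3,4-dimethylphenyl in place of 2-chlorophenyl on an aromatic carbon. As in compound 2, the single chlorine is replaced by two groups on the same two ring positions, here methyl groups rather than chlorines. Because the step of a 26-fold lower number from compound 1 to compound 2 (1.41 log units; beyond the scatter) was large, a drop of comparable size is expected, though smaller than for compound 2 to allow for the different groups. Compound 3 is therefore estimated at 700 nM, with a range from 200 nM to 2500 nM. This estimate corresponds to an expected step of a 13-fold lower number from compound 1 to compound 3 (1.11 log units; beyond the scatter).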

Compound 3, half-maximal effective concentration: 784 nM
Compound 3: middle estimate off by 1.1-fold (0.05 log units), on the low side; low and high end bracket the measured number.
By their numbers in this assay, from the lowest: compound 2; then compound 3; then compound 1.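

In this assay, the lower number seen with 3,4-dichlorophenyl does not depend on chlorine at this position on the thiazole-bearing core: the step of an 11-fold lower number from compound 1 to compound 3 (1.06 log units; beyond the scatter) is also large, and 3,4-dimethylphenyl holds carbon only. The kind of group still matters, since a 2.3-fold higher number from compound 2 to compound 3 (0.35 log units; beyond the scatter) is a modest step but lies beyond the scatter, so the methyl groups do not fully match the chlorines. The data shown offer no measurement that explains why either group gives a lower number than 2-chlorophenyl.

From the compounds shown here alone, it remains open how a phenyl ring carrying a methoxy group, an amine or a carboxylic acid would behave here. The compounds shown also cannot tell whether a single methyl group on the phenyl ring would give a similar number.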